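This account rests on a few compounds, and the source may have more. Where it says the series, first, only, none or still open, it means among the compounds named here.

Of the compounds shown here, three sharing one core have been measured in an ADME assay on MT4 cells (Homo sapiens) for cytotoxicity, read by MTT assay, with a stated time of 5 days; a lower number here means that less compound is tolerated, a higher number that more compound is tolerated. Compound 1 `CCCCN(c1ccnc(Nc2ccc(C#N)cc2)n1)c1c(F)cc(-c2ccc(C#N)cc2)cc1F` carries a propyl group on the saturated chain carbon bound to a nitrogen on an aromatic ring, and in this assay compound 1 gives 211000 nM. Compound 2 `N#Cc1ccc(Nc2nccc(N(CC3CCCC3)c3c(F)cc(-c4ccc(C#N)cc4)cc3F)n2)cc1` carries a cyclopentyl group at that carbon instead. For compound 2 the assay reports only a limit, > 247000 nM, and not a number; this is the limit of > 247000 nM in this assay, at which 1 of the 3 values shown sits. Compound 3 `N#CCN(c1ccnc(Nc2ccc(C#N)cc2)n1)c1c(F)cc(-c2ccc(C#N)cc2)cc1F` carries a cyano group at that carbon, and in this assay compound 3 gives 206000 nM. Compound 3 and compound 1 thus sit within the scatter of each other, and the remaining value is a limit, so no order among these three can be read from the numbers.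

Compound 4 `COCN(c1ccnc(Nc2ccc(C#N)cc2)n1)c1c(F)cc(-c2ccc(C#N)cc2)cc1F` has not yet been measured. It differs from compound 3 in one place: methoxy in place of cyano on a saturated chain carbon bound to a nitrogen on an aromatic ring. The measured steps that bear on changes at this carbon are a 1.0-fold lower number from compound 1 to compound 3 (0.01 log units; within the scatter) and an at least 1.1-fold lower number from compound 2 to compound 3 (0.07 log units; that floor lies within the scatter), neither of which moved the number beyond the scatter. Swapping propyl, cyclopentyl or cyano at this carbon left the number essentially where it was, so a methoxy group is expected to do the same. The step is estimated as a 1.0-fold higher number from compound 3 to compound 4 (0.01 log units; within the scatter). Compound 4 is therefore estimated at 210000 nM, with a range from 120000 nM to 300000 nM.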

Compound 4, half-maximal cytotoxic concentration: 238000 nM
Compound 4: middle estimate off by 1.1-fold (0.05 log units), on the low side; the measured number falls inside the stated range.
By their numbers in this assay, from the lowest: compounds 3, 1 and 4 (each within the scatter of the next). At a limit, above all of these: compound 2.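

Methoxy puts an oxygen-bearing group on this saturated chain carbon bound to a nitrogen on an aromatic ring, where the earlier compounds held propyl, cyclopentyl or cyano, and in this assay the swap for cyano gives a 1.2-fold higher number from compound 3 to compound 4 (0.06 log units; within the scatter). The swap for propyl gives a 1.1-fold higher number from compound 1 to compound 4 (0.05 log units; within the scatter), so among the compounds with full numbers, this oxygen-bearing group adds no step beyond the scatter to those already seen at this carbon. The swap for cyclopentyl gives an at least 1.0-fold lower number from compound 2 to compound 4 (0.01 log units; that floor lies within the scatter), which is only a floor and not a full step, since compound 2 has a limit and not a number: the limit of > 247000 nM in this assay, at which 1 of the 4 values shown sits.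

Going by these compounds, whether a group of a different kind at this carbon, such as an amine, a carboxylic acid or a longer chain, would also leave the number within the scatter remains open. The compounds shown vary only this one carbon, so it is also open whether a change elsewhere on the shared core would move the number in this assay.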